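The compounds below may be only part of what the source reports. "The series", "measured", "known", "first", "only" and "open" are said of these compounds alone.

Of the compounds shown here, three have been measured in a functional assay, with a stated time of 30 min; a lower number here means a stronger inhibitor, a higher number a weaker inhibitor. Compound 1 (`CCOc1cc(OC)c(Br)cc1C(C)=O`) gives 46800000 nM, compound 2 (`CCCCCCCCCCCCOc1cc(OC)c(Br)cc1C(C)=O`) gives 29500000 nM, and compound 3 (`CCOc1cc(OC)ccc1C(C)=O`) gives 39600000 nM. Compound 3 thus stands within the scatter of both other compounds, and its number does not separate from theirs. The next compound, compound 4 (`CCCCCCCCOc1cc(OC)ccc1C(C)=O`), differs from compound 3 by hexyl in place of hydrogen on a saturated chain carbon, two bonds along the chain from an oxygen on an aromatic ring. The only measured step between two of these compounds, a 1.2-fold lower number from compound 1 to compound 3 (0.07 log units; within the scatter), puts hydrogen in place of bromo on an aromatic carbon, so it does not touch the chain, and it stays within the scatter. Closer to the point, compound 2 has a long chain where compound 1 has a short one, yet compound 2 gives 29500000 nM and compound 1 gives 46800000 nM, and these two values lie close together. No change beyond the scatter is therefore expected in this assay. The expected step is small, an estimated 1.1-fold lower number from compound 3 to compound 4 (0.05 log units; within the scatter). For compound 4 the estimated value is 35000000 nM, with a range from 15000000 nM to 75000000 nM.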

Compound 4, half-maximal inhibitory concentration: 40000000 nM
Compound 4: the middle estimate sits 1.1-fold (0.06 log units) below what was measured, and the stated range covers the measured number.
By their numbers in this assay, from the lowest: compounds 2, 3, 4 and 1 (each within the scatter of the next).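

In this assay, hexyl in place of hydrogen on a saturated chain carbon, two bonds along the chain from an oxygen on an aromatic ring, gives a 1.0-fold higher number from compound 3 to compound 4 (0.00 log units; within the scatter) and so stays within the scatter. This is the first listed step at this position, since the only earlier step concerned bromo on an aromatic carbon. On the core of compound 3, the position therefore accepts hexyl with no change that can be told from the scatter, although the numbers of both compounds remain very high. No measurement shown here offers an explanation for this result. As far as these compounds go, whether an amine, a carboxylic acid or a longer chain at this position would give a step beyond the scatter remains open. So does whether hexyl would give the same small step on the core of compound 1, which carries bromo.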